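Compound 2 to compound 3: fluoro replaced by hydrogen

The compounds below may be only part of what the source reports. "The series", "measured", "known", "first", "only" and "open" are said of these compounds alone.

In a functional assay on the whole organism for inhibition, with Mus musculus as the target (on this read-out higher numbers stand for an effect only at larger amounts of compound and lower numbers for an effect already at smaller amounts), compound 1 `NCC(=O)NCc1nncn1-c1ccc(Cl)cc1C(=O)c1ccccc1` gives 31.7 mg/kg while compound 2 `Cc1nnc(CNC(=O)CN)n1-c1ccc(Cl)cc1C(=O)c1ccccc1F` gives 1.52 mg/kg and so holds the lower of the two numbers, by a margin beyond the usual scatter.

Compound 3 `Cc1nnc(CNC(=O)CN)n1-c1ccc(Cl)cc1C(=O)c1ccccc1` takes compound 2 and puts hydrogen in place of fluoro on an aromatic carbon, ortho to a large group hydrogen in place of fluoro on an aromatic carbon with the rest of the structure unchanged. Within the data shown here, no measured pair shows this change alone, so the expectation has no direct precedent. It starts from compound 2 (1.52 mg/kg) and treats compound 1 (31.7 mg/kg) as the high end of the numbers seen so far.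

A modest move toward larger doses in this assay is expected, with an estimated 2.6-fold higher number from compound 2 to compound 3 (0.42 log units; beyond the scatter) that may not clear the scatter by much. For compound 3 the expected value is 4 mg/kg (estimated range 1.3 mg/kg to 13 mg/kg).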

Compound 3, dose for half-maximal effect: 4.25 mg/kg
The estimate for compound 3 lay 1.1-fold (0.03 log units) below the measured number; low and high end bracket the measured number.
By their numbers in this assay, from the lowest: compound 2; then compound 3; then compound 1.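

In this assay, among these compounds, going from 2-fluorophenyl to phenyl gives a 2.8-fold higher number from compound 2 to compound 3 (0.45 log units; beyond the scatter), the first single-place reading at this position: fluoro here goes with effect at smaller doses, although the step is modest. Compound 3 also opens a second single-place comparison, since methyl in place of hydrogen on an aromatic carbon gives a 7.5-fold lower number from compound 1 to compound 3 (0.87 log units; beyond the scatter), so the position outside the benzoyl part also moves the dose in this series. Nothing available explains either step.

Going by these compounds, whether trifluoromethyl or methoxy in place of fluoro would give a lower or higher number than fluoro remains open, as does the effect of ethyl in place of the methyl. Also open, on these data alone, is whether the fluoro step keeps its size on a core without that methyl.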